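Amine-ester series: cytotoxicity notes toward compound 3

A few compounds are considered here, and "the series" means these few. Any claim that something is new, unique, unknown or untested is made for them only; others in the source may bear on it.

Measured so far:
- compound 1 `CN1CCN(CCC(=O)O[C@@H]2C[C@@H]3CC[C@@]2(C)C3(C)C)CC1`: 48100 nM
- compound 2 `CCN1CCN(CCC(=O)O[C@@H]2C[C@@H]3CC[C@@]2(C)C3(C)C)CC1`: 105000 nM

In an ADME assay on MDCK cells (Canis lupus familiaris) for cytotoxicity, read by MTT assay, with a stated time of 48 h (on this read-out lower numbers stand for higher toxicity in this test and higher numbers for lower toxicity in this test), compound 1 gives 48100 nM, the lowest of the two numbers; its nearest neighbour is compound 2, and the step of a 2.2-fold higher number from compound 1 to compound 2 (0.34 log units; beyond the scatter) is modest. Compound 3 `CC1(C)[C@H]2CC[C@]1(C)[C@H](OC(=O)CCN1CCCC1)C2` is not yet measured. It differs from compound 1 by pyrrolidin-1-yl in place of 4-methylpiperazin-1-yl on a saturated chain carbon, two bonds along the chain from a carbonyl carbon. Among the measured compounds shown here, no measured step touches this change: the one step recorded concerns only the substituent on the ring nitrogen of the 4-methylpiperazin-1-yl group, and it was modest. That step gives no direction for exchanging the whole ring. The expectation is therefore a step of a 1.0-fold higher number from compound 1 to compound 3 (0.02 log units; within the scatter) that stays within the scatter, in no firm direction. Compound 3 is estimated to give 50000 nM in this assay, with an expected range from 20000 nM to 125000 nM.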

Compound 3, half-maximal cytotoxic concentration: 125000 nM
For compound 3 the middle estimate is 2.5-fold (0.40 log units) below the measured one, within the range that was stated.
By their numbers in this assay, from the lowest: compound 1; then compounds 2 and 3 (each within the scatter of the next).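

In this assay, replacing the whole ring on this saturated chain carbon gives a 2.6-fold higher number from compound 1 to compound 3 (0.41 log units; beyond the scatter), so the number responds to the ring itself, not only to the substituent on the ring nitrogen seen in the earlier step. Among the compounds shown here, the single step changes ring size and the count of ring hetero atoms together, and it cannot separate the two. No measured evidence accounts for the step.

Piperidin-1-yl at the same place would keep the single ring nitrogen of pyrrolidin-1-yl in a six-membered ring, while morpholin-4-yl would put an oxygen in the ring position of the methyl-bearing nitrogen of compound 1, so either could help to divide the step. The compounds shown also leave open whether the step holds with a longer chain from the carbonyl carbon to the ring.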